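Working notes: from compound 2 to compound 4

A few compounds are considered here, and "the series" means these few. Any claim that something is new, unique, unknown or untested is made for them only; others in the source may bear on it.

Compound 1 (`CC(C)CNC(=O)n1c(=O)oc2ccc(C3CCN(C)CC3)cc21`) stands at 0.5 h in an ADME assay on a cell-free system (plasma, Mus musculus) for metabolic stability, read by LC-MS, tested at 2 uM (on this read-out lower numbers stand for a shorter-lived compound and higher numbers for a longer-lived compound), and compound 3 (`CN1CCC(c2ccc3c(c2)oc(=O)n3C(=O)NCCCCc2ccc(F)cc2)CC1`) at 0.333 h on the same read-out. Compound 2 (`CC(C)N1CCC(c2ccc3c(c2)oc(=O)n3C(=O)NCCCCc2ccccc2)CC1`) gives 0.667 h and lies within the scatter of both, so these three numbers cannot be ranked.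

Compound 4 (`CN1CCC(c2ccc3c(c2)oc(=O)n3C(=O)NCCCCc2ccccc2)CC1=O`) has not yet been measured. The structural change from compound 2 is 1-methyl-2-oxopiperidin-4-yl in place of 1-isopropylpiperidin-4-yl on an aromatic carbon and it sits on an aromatic carbon, meta to a fused ring and para to a fused ring: 1-methyl-2-oxopiperidin-4-yl replaces 1-isopropylpiperidin-4-yl.

Among the compounds with values here, no measured pair differs in one place only, so the series offers no direct step for this change. With compound 3 at 0.333 h and compound 2 at 0.667 h within the scatter of each other, no step beyond the scatter is expected in this assay for this change, and no firm direction. The expected step is a 1.1-fold lower number from compound 2 to compound 4 (0.05 log units; within the scatter) and it is estimated to stay within the scatter. Compound 4 is estimated at 0.6 h with an expected range of 0.25 h to 1.5 h for a single measurement.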

Compound 4, half-life: 0.6 h
Beside the measured number, compound 4's estimate shows no gap at the digits printed; low and high end bracket the measured number.
By their numbers in this assay, from the lowest: compounds 3, 1, 4 and 2 (each within the scatter of the next).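

Within the data shown here, the only one-place step so far exchanges 1-isopropylpiperidin-4-yl for 1-methyl-2-oxopiperidin-4-yl on the aromatic carbon, and this assay reads a 1.1-fold lower number from compound 2 to compound 4 (0.05 log units; within the scatter), so this position takes the exchange with no step beyond the scatter. The change is a double one, adding a ring carbonyl and replacing isopropyl with methyl on the ring nitrogen, and this single step shows only the two together. No supporting data bear on this result, so it carries no explanation.

The compounds shown leave open what each part does alone, a question that 1-methylpiperidin-4-yl or 1-isopropyl-2-oxopiperidin-4-yl at this place, with the rest of compound 2 kept, would separate. Also open, from the compounds shown here alone, is whether an open-chain amine or a carboxylic acid here would produce a step beyond the scatter.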